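Notes on removing fluoro from compound 2

The compounds below may be only part of what the source reports. "The series", "measured", "known", "first", "only" and "open" are said of these compounds alone.

Measured in a functional assay on A549 cells (Homo sapiens) for antiproliferative activity, read by MTT assay, with a stated time of 72 h; on this read-out lower numbers stand for stronger inhibition and higher numbers for weaker inhibition:
- compound 1 `CN(C)CCn1cccc1/C=N/NC(=O)Nc1ccc(Oc2ccnc3[nH]ccc23)c(F)c1`: "not active" (no number reported)
- compound 2 `CN1CCN(CCCn2cccc2/C=N/NC(=O)Nc2ccc(Oc3ccnc4[nH]ccc34)c(F)c2)CC1`: 2200 nM
- compound 3 `O=C(N/N=C/c1cccn1CCCN1CCCC1)Nc1ccc(Oc2ccnc3[nH]ccc23)c(F)c1`: 2010 nM

Among the compounds with values here, compound 2 lies within the scatter of compound 3, the only other compound with a number, while compound 1 gave no number. Compound 4 `CN1CCN(CCCn2cccc2/C=N/NC(=O)Nc2ccc(Oc3ccnc4[nH]ccc34)cc2)CC1` differs from compound 2 by hydrogen in place of fluoro on an aromatic carbon. Within the data shown here, no measured step touches that carbon. Among the measured compounds shown here, the single available step, a 1.1-fold lower number from compound 2 to compound 3 (0.04 log units; within the scatter), concerns pyrrolidin-1-yl in place of 4-methylpiperazin-1-yl and gives no direction for this change. No step beyond the scatter is therefore expected in this assay, though this rests on little evidence. The expected step is a 1.1-fold higher number from compound 2 to compound 4 (0.04 log units; within the scatter). Compound 4 is estimated at 2400 nM, with an expected range of 900 nM to 6500 nM.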

Compound 4, half-maximal inhibitory concentration: 1640 nM
Compound 4: middle estimate off by 1.5-fold (0.17 log units), on the high side, and the stated range covers the measured number.
By their numbers in this assay, from the lowest: compounds 4, 3 and 2 (each within the scatter of the next).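

Hydrogen in place of fluoro on this aromatic carbon, ortho to a large group and meta to a large group, leaves compound 4 within the scatter of compound 2 in this assay (a 1.3-fold lower number from compound 2 to compound 4 (0.13 log units; within the scatter)). Within the data shown here, this is the first reading at this position, and with 4-methylpiperazin-1-yl on the chain the number does not depend on the fluorine atom. No measurement shown bears on a cause for this result.

As far as these compounds go, whether chloro, methyl or methoxy on the same carbon would read differently stays open. So does whether hydrogen there gives the same outcome with the pyrrolidin-1-yl chain of compound 3.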